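The compounds below may be only part of what the source reports. "The series", "measured", "known", "first", "only" and "open" are said of these compounds alone.

Series notes.

Compound 1 `CC1(C)CC(=O)c2cc(C#N)c(SCc3ccccc3)nc2C1`: in an assay on isolated protein for displacement of a labelled ligand from metabotropic glutamate receptor 5 (Rattus norvegicus) (a lower number here means a stronger inhibitor, a higher number a weaker inhibitor), compound 1 gives 57000 nM.
Compound 2 `CC1(C)CC(=O)c2cc(Br)c(N3CCN(c4ccc(F)cc4)CC3)nc2C1`: in this assay compound 2 gives 37000 nM.
Compound 3 `C(#Cc1ccc2c(n1)CCCC2)c1ccccc1`: in this assay compound 3 gives 510 nM.

Compound 3 holds the lowest number of the three, and its gaps to compound 2 and to compound 1 both lie well beyond the scatter. Within the data shown here, no single-point step connects compound 3 to either of them, so those two pairs show only that the values differ.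

Compound 4 `COC1CCCc2nc(C#Cc3ccccc3)ccc21` differs from compound 3 by methoxy in place of hydrogen on a saturated ring carbon. Among the measured compounds shown here, no measured step of this kind exists in the set. The expected step is small, none beyond the scatter, as a 1.1-fold lower number from compound 3 to compound 4 (0.05 log units; within the scatter). Compound 4 is therefore estimated at 450 nM in this assay, with an expected range from 120 nM to 1800 nM.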

Compound 4, half-maximal inhibitory concentration: 80 nM
Compound 4: middle estimate off by 5.6-fold (0.75 log units), on the high side, outside the stated range (below it).
By their numbers in this assay, from the lowest: compound 4; then compound 3; then compounds 2 and 1 (each within the scatter of the next).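

Methoxy in place of hydrogen on this saturated ring carbon gives a 6.4-fold lower number from compound 3 to compound 4 (0.80 log units; beyond the scatter) in this assay and provides the series' first readable single-point step. The earlier compounds shown here gave no information on this position, and it now shows that a change here can move the number beyond the scatter. Nothing available accounts for the size of this step.

On these data alone, whether a hydroxyl, an ethoxy or an amine on the same ring carbon would give a similar step remains open. Whether a methoxy step of this kind would carry over to the cores of compound 1 or compound 2 is also unresolved.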